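From Ethyl to Pentyl on the Ring Amine Nitrogen

The source may report more compounds than this note shows. Statements on the series, on what has been measured and on what is new or still open speak of the compounds shown alone.

In a functional assay on HEK293 cells for agonist activity at 5-hydroxytryptamine receptor 4 (Homo sapiens), read by cAMP accumulation (a higher number here means that more compound is needed for the effect, a lower number that less compound is needed), compound 1 `COc1cc(N)c(Cl)cc1C(=O)NC1CCNCC1` gives 398 nM.
In this assay compound 2 `CCN1CCC(NC(=O)c2cc(Cl)c(N)cc2OC)CC1` gives 79.4 nM.

Within the data shown here, compound 2 holds the lower of the two numbers measured, and the single step that separates it from compound 1 is a 5.0-fold lower number from compound 1 to compound 2 (0.70 log units; beyond the scatter), an ethyl in place of hydrogen on an amine nitrogen in a ring. Compound 3 `CCCCCN1CCC(NC(=O)c2cc(Cl)c(N)cc2OC)CC1` differs from compound 2 by propyl in place of hydrogen on a saturated chain carbon, two bonds along the chain from an amine nitrogen in a ring; cut one bond further out, the same difference reads methyl to butyl, ethyl to pentyl. Among the measured compounds shown here, only that one measured step bears on the present change, and it concerns the first carbons placed on the ring amine nitrogen rather than a chain grown beyond an ethyl. For the measured compounds named here, no measured pair shows what further lengthening does, so the expectation rests on the earlier step alone and is held loosely: for compound 3 a step of a 1.3-fold lower number from compound 2 to compound 3 (0.12 log units; within the scatter) is expected, within the scatter or a little beyond. Compound 3 is therefore estimated at 60 nM, in a range from 15 nM to 250 nM.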

Compound 3, half-maximal effective concentration: 25.1 nM
The estimate for compound 3 lay 2.4-fold (0.38 log units) above the measured number, within the range that was stated.
By their numbers in this assay, from the lowest: compound 3; then compound 2; then compound 1.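

Among these compounds, the chain on the amine nitrogen in a ring still pays beyond ethyl: in this assay the longer pentyl chain brings a 3.2-fold lower number from compound 2 to compound 3 (0.50 log units; beyond the scatter) and so extends a trend that the earlier compounds showed only for the first carbons placed there. Measured from the free ring amine, the whole change to pentyl comes to a 16-fold lower number from compound 1 to compound 3 (1.20 log units; beyond the scatter) and ranks as a large step, and none of the three compounds goes against the order of falling numbers with growing chain length. Nothing available here gives a reason for this trend.

On these data alone, whether the numbers keep falling with a chain longer than pentyl, or pass through a minimum at propyl or butyl, stays open. So does the effect of a chain ending in a hydroxyl, an amine or a phenyl ring on this nitrogen.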